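A few compounds are considered here, and "the series" means these few. Any claim that something is new, unique, unknown or untested is made for them only; others in the source may bear on it.

Series notes. The shared core is carried by compound 1 `c1ccc(-c2cn3ccnc3c(-c3ccc4ncn(C5CCCCC5)c4c3)n2)cc1`, compound 2 `Fc1ccc(-c2cn3ccnc3c(-c3ccc4ncn(C5CCCCC5)c4c3)n2)cc1` and compound 3 `Cc1cccc(-c2cn3ccnc3c(-c3ccc4ncn(Cc5ccccc5)c4c3)n2)c1`. In a functional assay on MOLT-4 cells (Homo sapiens) for inhibition, read by sulforhodamine B assay, with a stated time of 48 h, tested at 10 uM (a higher number here means more inhibition at the concentration tested (going by the name of the read-out), a lower number less inhibition), compound 1 gives 67.7%, compound 2 gives 25.2%, and compound 3 gives 36.9%. Compound 3 stands second highest of the three numbers in this assay; compound 2 is nearest, compound 1 furthest, both gaps beyond the scatter. Going by the values given here, the one measured step, a number 42.5 percentage points lower from compound 1 to compound 2 (beyond the scatter), is large, but it concerns fluoro in place of hydrogen and not the change now at hand.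

Compound 4 `c1ccc(Cn2cnc3ccc(-c4nc(-c5cccc6ccccc56)cn5ccnc45)cc32)cc1` differs from compound 3 by naphthalen-1-yl in place of 3-methylphenyl on an aromatic carbon. Among the compounds with values here, nothing measured bears directly on this exchange; the single step in this assay concerns a different change, so it gives only a sense of how far this position can move. The expectation for compound 4 is therefore a step of uncertain direction, a number 3.1 percentage points higher from compound 3 to compound 4 (within the scatter), not clearly beyond the scatter. Compound 4 is expected at 40% in this assay, with a range from 20% to 62%.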

Compound 4, a percentage reported as inhibition, at one concentration (the size of the read-out at that concentration, not a potency): 22.3%
Beside the measured number, compound 4's estimate is 17.7 percentage points above it; measured number inside the range.
By their numbers in this assay, from the lowest: compounds 4 and 2 (each within the scatter of the next); then compound 3; then compound 1.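

In this assay, the exchange of 3-methylphenyl for naphthalen-1-yl gives a number 14.6 percentage points lower from compound 3 to compound 4 (beyond the scatter) and so shows that this position responds to a change of the whole aromatic group, not only to a fluoro on it. The two steps now measured at this group both go downward, but they stand on different compounds, one carrying cyclohexyl and the other the benzyl-type group of compound 3, so they do not make a shared trend. No measurement given here accounts for this step.

On these data alone, whether the fall follows the second aromatic ring or the loss of the methyl remains open, and naphthalen-2-yl on the compound 3 background would separate little of this without plain phenyl beside it. Also open, as far as these compounds go, is how an amine or a carboxylic acid on this aromatic group would read in this assay on either background.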